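From Methoxy to Fluoro: Estimating Compound 3

This account rests on a few compounds, and the source may have more. Where it says the series, first, only, none or still open, it means among the compounds named here.

For the measured compounds named here, compound 2 `COc1ccc(-c2nn(-c3ccccc3)cc2C(=O)NC(=S)Nc2ccc(Cl)cc2)cc1` gives 1310 nM in a functional assay on A549 cells (Homo sapiens) for inhibition, read by CCK-8 assay, with a stated time of 48 h (a higher number here means a weaker inhibitor, a lower number a stronger inhibitor), the lowest of the two numbers measured so far; its nearest neighbour, compound 1 `O=C(NC(=S)Nc1ccc(Cl)cc1)c1cn(-c2ccccc2)nc1-c1ccc(Cl)cc1`, gives 3150 nM. Compound 3 `O=C(NC(=S)Nc1ccc(Cl)cc1)c1cn(-c2ccccc2)nc1-c1ccc(F)cc1` differs from compound 2 by a single change: fluoro in place of methoxy on an aromatic carbon. Going by the values given here, the only measured step, a 2.4-fold lower number from compound 1 to compound 2 (0.38 log units; beyond the scatter), bears on this, since it also exchanges a halogen and a methoxy at the same place, though in the opposite direction. Partly reversing that step, compound 3 is expected to give a somewhat higher number, a 1.7-fold higher number from compound 2 to compound 3 (0.23 log units; within the scatter). The estimate for compound 3 is 2200 nM, with a range from 1000 nM to 5000 nM.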

Compound 3, half-maximal inhibitory concentration: 2990 nM
Compound 3: middle estimate off by 1.4-fold (0.13 log units), on the low side, and the stated range covers the measured number.
By their numbers in this assay, from the lowest: compound 2; then compounds 3 and 1 (each within the scatter of the next).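

In this assay, fluoro in place of methoxy gives a 2.3-fold higher number from compound 2 to compound 3 (0.36 log units; beyond the scatter), while fluoro in place of chloro gives a 1.1-fold lower number from compound 1 to compound 3 (0.02 log units; within the scatter), so the two halogens cannot be told apart at this place on the ring. Among these three compounds, only the methoxy group of compound 2 stands apart from the others. No evidence here explains that difference. Still open, on these data alone, is whether an amine, a hydroxyl or a longer chain such as ethoxy at this place would match methoxy, or whether this gap would hold on another core.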